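Enlarging the amine on the pyridinyl group of the core

The source may report more compounds than this note shows. Statements on the series, on what has been measured and on what is new or still open speak of the compounds shown alone.

The shared core of compound 1 `CCCN(CCC)c1cc(C)nc2c(-c3ccc(Cl)cn3)c(C)nn12` carries a 5-chloropyridin-2-yl group, and in an assay on isolated protein for binding affinity to corticotropin-releasing factor receptor 1 (Homo sapiens) (a higher number here means a weaker inhibitor, a lower number a stronger inhibitor), compound 1 gives 88 nM. Compound 2 `CCCN(CCC)c1cc(C)nc2c(-c3ncc(N)cc3C)c(C)nn12` carries a 5-amino-3-methylpyridin-2-yl group there instead and gives 85 nM in this assay; the step of a 1.0-fold lower number from compound 1 to compound 2 (0.02 log units; within the scatter). Compound 3 `CCCN(CCC)c1cc(C)nc2c(-c3ncc(NC)cc3C)c(C)nn12` adds a methyl to that amine nitrogen and gives 40 nM, the lowest of the three numbers; the step of a 2.1-fold lower number from compound 2 to compound 3 (0.33 log units; beyond the scatter), and the step of a 2.2-fold lower number from compound 1 to compound 3 (0.34 log units; beyond the scatter). Compound 4 `CCCN(CCC)c1cc(C)nc2c(-c3ncc(N4CCCCC4)cc3C)c(C)nn12` takes this a stage further: piperidin-1-yl in place of methylamino on an aromatic carbon. The measured step that bears on this change is the one from a free amine to a methylated amine, which was modest in size and lowered the number. Enlarging the nitrogen substituent again might continue in the same direction, but with only one such step to lean on, the expected change is small and uncertain. Compound 4 is therefore estimated at 30 nM, within a range of 12 nM to 80 nM. That estimate corresponds to an expected step of a 1.3-fold lower number from compound 3 to compound 4 (0.12 log units; within the scatter).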

Compound 4, inhibition constant: 17 nM
Compound 4: the middle estimate sits 1.8-fold (0.25 log units) above what was measured; measured number inside the range.
By their numbers in this assay, from the lowest: compound 4; then compound 3; then compounds 2 and 1 (each within the scatter of the next).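

In this assay, the number keeps falling as the amine grows: the change from methylamino to piperidin-1-yl gives a 2.4-fold lower number from compound 3 to compound 4 (0.37 log units; beyond the scatter), and the full change from amino gives a 5.0-fold lower number from compound 2 to compound 4 (0.70 log units; beyond the scatter). This position therefore accepts a six-membered non-aromatic ring of 6 heavy atoms, and the nitrogen substituent can lose its hydrogen-bond donor without the number rising, which compounds 2 and 3, both of which keep that donor, could not show. No measurement shown explains why the number falls.

The step to compound 4 changes the size of the group, adds a ring and removes the donor all at once, so a dimethylamino group would help separate these changes. A morpholin-4-yl or azepan-1-yl group would show whether the trend continues with an added ring oxygen or a larger ring.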